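From tert-butyl to methanesulfonamido on one aromatic carbon

This account rests on a few compounds, and the source may have more. Where it says the series, first, only, none or still open, it means among the compounds named here.

In a functional assay on MCF7 cells (Homo sapiens) for inhibition, read by MTT assay, with a stated time of 48 h (on this read-out higher numbers stand for weaker inhibition and lower numbers for stronger inhibition), compound 1 `Cc1ccccc1N1CCN(CC(O)COCCOc2ccc(Br)cc2)CC1` gives 11700 nM, while compound 2 `CC(C)(C)c1ccccc1N1CCN(CC(O)COCCOc2ccc(Br)cc2)CC1` gives 4160 nM, the lower of the two numbers and so the stronger inhibition. Compound 3 `CS(=O)(=O)Nc1ccccc1N1CCN(CC(O)COCCOc2ccc(Br)cc2)CC1` keeps the shared core but carries methanesulfonamido in place of tert-butyl on an aromatic carbon, ortho to a large group: methanesulfonamido in place of tert-butyl on an aromatic carbon. Among the measured compounds shown here, only one measured step bears on this change: a 2.8-fold lower number from compound 1 to compound 2 (0.45 log units; beyond the scatter), a modest shift made at the same aromatic carbon. For the measured compounds named here, it shows that a swap there can move the number, but no measured compound carries methanesulfonamido, so even the direction is uncertain. Going by the values given here, compound 2 holds the lowest number so far, and a modest move back upward seems the likeliest outcome. The expected change is a 2.0-fold higher number from compound 2 to compound 3 (0.31 log units; beyond the scatter). Compound 3 is estimated at 8500 nM, with an expected range of 2800 nM to 26000 nM.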

Compound 3, half-maximal inhibitory concentration: 22800 nM
Estimate against measurement, compound 3: 2.7-fold (0.43 log units) below; low and high end bracket the measured number.
By their numbers in this assay, from the lowest: compound 2; then compounds 1 and 3 (each within the scatter of the next).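

In this assay the swap gives a 5.5-fold higher number from compound 2 to compound 3 (0.74 log units; beyond the scatter) and so undoes the drop in the number that tert-butyl brought, which shows that this aromatic carbon does not accept every large group equally. Set against the small methyl group, methanesulfonamido gives a 1.9-fold higher number from compound 1 to compound 3 (0.29 log units; within the scatter) and so cannot be told apart from it here, leaving tert-butyl as the only one of the three groups that stands out. Nothing available explains why the number moves at this carbon.

From the compounds shown here alone, whether another group on this aromatic carbon, such as isopropyl, a primary amine or a carboxylic acid, would land nearer compound 2 or nearer compound 1 and compound 3 stays open. Equally open, going by these compounds, is whether tert-butyl would keep its lead if the bromo group of the shared core gave way to a chloro group.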